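This account rests on a few compounds, and the source may have more. Where it says the series, first, only, none or still open, it means among the compounds named here.

Measured so far:
compound 1 `O=S(=O)(NCCCNc1nccc(-c2c(-c3cccc(F)c3)nc3sccn23)n1)c1ccc(Br)cc1` — 7040 nM
compound 2 `O=C(NCCNc1nccc(-c2c(-c3cccc(F)c3)nc3sccn23)n1)c1ccc(C(F)(F)F)cc1` — 8710 nM
compound 3 `O=C(NCCNc1nccc(-c2c(-c3cccc(F)c3)nc3sccn23)n1)c1ccc(Cl)cc1` — 2570 nM

Three compounds share one core and differ only in the side chain attached to it. In a functional assay on A-375 cells (Homo sapiens) for cytotoxicity, read by MTT assay (on this read-out higher numbers stand for weaker inhibition and lower numbers for stronger inhibition), compound 3 gives the lowest number of the three; compound 1 lies a 2.7-fold lower number from compound 1 to compound 3 (0.44 log units; beyond the scatter) away, and compound 2 lies a 3.4-fold lower number from compound 2 to compound 3 (0.53 log units; beyond the scatter) away, both steps beyond the scatter.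

Compound 4 `Cc1ccc(C(=O)NCCNc2nccc(-c3c(-c4cccc(F)c4)nc4sccn34)n2)cc1` has not been measured. It differs from compound 3 in one place: methyl in place of chloro on an aromatic carbon. The aromatic ring, the carbonyl and the chain are unchanged.

Among the measured compounds shown here, of the two measured steps, only the one from compound 2 to compound 3 touches the same spot: there, a change on that aromatic carbon gave a 3.4-fold lower number from compound 2 to compound 3 (0.53 log units; beyond the scatter), a modest step. The step from compound 1 to compound 3 changed a larger part of the chain and says little about a single swap on the ring. So a change at this position can move this assay by a modest amount, but with one such swap recorded there is no way to tell in which direction a methyl will move it. The expected step for compound 4 is therefore small, a 1.4-fold higher number from compound 3 to compound 4 (0.13 log units; within the scatter), and may not exceed the scatter. Compound 4 is estimated at 3500 nM, with a range from 1500 nM to 8500 nM.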

Compound 4, half-maximal inhibitory concentration: 5880 nM
Estimate against measurement, compound 4: 1.7-fold (0.23 log units) below; the measured number falls inside the stated range.
By their numbers in this assay, from the lowest: compound 3; then compounds 4, 1 and 2 (each within the scatter of the next).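

In this assay, the earlier swap at this aromatic carbon gave no direction for a new group, but now two replacements of chloro can be compared, and both give higher numbers: methyl gives a 2.3-fold higher number from compound 3 to compound 4 (0.36 log units; beyond the scatter), in line with the earlier swap of trifluoromethyl for chloro. Methyl and trifluoromethyl themselves cannot be told apart, with a 1.5-fold lower number from compound 2 to compound 4 (0.17 log units; within the scatter), so among the three groups seen on this carbon, chloro alone stands out, and compound 3 keeps the lowest number. Once chloro is gone, the larger change in the side chain also stops registering, since a 1.2-fold lower number from compound 1 to compound 4 (0.08 log units; within the scatter) leaves the sulfonyl compound and the methyl amide within the scatter of each other.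

No measurement shown explains why chloro and methyl differ on this carbon. On these data alone, whether chloro is unusual or merely one of several groups that work here remains open, and fluoro, methoxy or an amine on the same carbon would help to settle that.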